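The source may hold more compounds than are shown below. What is called first, only, known or untested is meant among the compounds shown, and "the series" means these compounds.

Going by the values given here, in a functional assay on MCF7 cells (Homo sapiens) for antiproliferative activity, read by MTT assay, with a stated time of 48 h (on this read-out higher numbers stand for weaker inhibition and lower numbers for stronger inhibition), compound 1 (`COc1ccccc1N1CCN(C(=O)/C=C/c2ccc(O)c(O)c2)CC1`) gives 0.54 ug/mL and compound 2 (`COc1cccc(N2CCN(C(=O)/C=C/c3ccc(O)c(O)c3)CC2)c1`) gives 0.92 ug/mL, so compound 2 stands within the scatter of the only other measured compound. Compound 3 (`Cc1ccc(N2CCN(C(=O)/C=C/c3ccc(O)c(O)c3)CC2)c(C)c1`) differs from compound 2 as follows: 2,4-dimethylphenyl in place of 3-methoxyphenyl on an amine nitrogen in a ring. It carries 2,4-dimethylphenyl in place of 3-methoxyphenyl on an amine nitrogen in a ring. Among the compounds with values here, the one measured step at this place is a 1.7-fold higher number from compound 1 to compound 2 (0.23 log units; within the scatter), so no change beyond the scatter is expected in this assay. The expected step is a 1.2-fold lower number from compound 2 to compound 3 (0.06 log units; within the scatter). For compound 3 the estimated value is 0.8 ug/mL, with an expected range of 0.3 ug/mL to 2.2 ug/mL.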

Compound 3, half-maximal inhibitory concentration: 0.78 ug/mL
The estimate for compound 3 lay 1.0-fold (0.01 log units) above the measured number; low and high end bracket the measured number.
By their numbers in this assay, from the lowest: compounds 1, 3 and 2 (each within the scatter of the next).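

In this assay, putting 2,4-dimethylphenyl in place of 3-methoxyphenyl on the ring amine nitrogen gives a 1.2-fold lower number from compound 2 to compound 3 (0.07 log units; within the scatter), and putting it in place of 2-methoxyphenyl gives a 1.4-fold higher number from compound 1 to compound 3 (0.16 log units; within the scatter). Going by these compounds alone, the earlier pair compared only two methoxyphenyl groups, whereas these steps show that an entering group with no oxygen and no hydrogen-bond acceptor also stays within the scatter at this position. Nothing available gives a reason for this. On these data alone, whether a phenyl ring bearing an amine or a carboxylic acid, or a cyclohexyl group, would move the number beyond the scatter remains open.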